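The compounds below may be only part of what the source reports. "The series", "measured", "known", "first", "only" and "open" are said of these compounds alone.

Of the compounds shown here, three built on one shared core have been tested so far: compound 1 `CCc1ccc(Nc2cc(NC(=O)Nc3cc(OC)cc(OC)c3)ncn2)cc1`, compound 2 `COc1cc(NC(=O)Nc2cc(Nc3cccc(C(C)(C)C)c3)ncn2)cc(OC)c1` and compound 3 `COc1cc(NC(=O)Nc2cc(Nc3cc(C(F)(F)F)ccc3OC)ncn2)cc(OC)c1`. In a functional assay on HCC827 cells (Homo sapiens) for inhibition, read by MTT assay, with a stated time of 48 h, tested at 10 uM (a higher number here means more inhibition at the concentration tested (going by the name of the read-out), a lower number less inhibition), compound 1 gives 66.2%. In the same assay compound 2 gives 48.7%, and compound 3 gives 59.7%. Compound 3 therefore sits close to compound 1, within the usual scatter, while its number lies clearly above that of compound 2, beyond the scatter.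

For the measured compounds named here, only one single-point step has been measured, a number 17.5 percentage points lower from compound 1 to compound 2 (beyond the scatter), and it concerns the aryl group attached to the nitrogen, not the substituent pattern on that ring.

Compound 4 `COc1cc(NC(=O)Nc2cc(Nc3cc(I)ccc3OC)ncn2)cc(OC)c1` has not yet been measured. Its difference from compound 3 is iodo in place of trifluoromethyl on an aromatic carbon. Going by the values given here, no measured step touches this kind of exchange, so there is nothing in the numbers that points to a rise or a fall; the most that can be said is that the rest of the molecule is unchanged and compound 3 already sits in the middle of the range seen. Compound 4 is therefore expected to give about 58% in this assay, in the range from 44% to 72%. This estimate corresponds to an expected step of a number 1.7 percentage points lower from compound 3 to compound 4 (within the scatter), that is, no change beyond the scatter.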

Compound 4, a percentage reported as inhibition, at one concentration (the size of the read-out at that concentration, not a potency): 71%
Compound 4: the middle estimate sits 13 percentage points below what was measured, and the stated range covers the measured number.
By their numbers in this assay, from the lowest: compound 2; then compounds 3, 1 and 4 (each within the scatter of the next, the first and the last beyond it).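

In this assay, for the compounds shown here, the exchange of trifluoromethyl for iodo on the aromatic carbon para to a methoxy group gives a number 11.3 percentage points higher from compound 3 to compound 4 (beyond the scatter) and is the first measured change at this position, which shows that the group placed there can shift the read-out beyond the scatter, even when one iodine atom stands where four heavy atoms stood. Taken as whole aryl groups on the nitrogen, 5-iodo-2-methoxyphenyl in place of 3-(tert-butyl)phenyl gives a number 22.3 percentage points higher from compound 2 to compound 4 (beyond the scatter) and stands apart from that group, whereas 5-iodo-2-methoxyphenyl in place of 4-ethylphenyl gives a number 4.8 percentage points higher from compound 1 to compound 4 (within the scatter) and so cannot be told apart from that group in this read-out. Nothing measured here gives a reason for the step at this position.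

With only trifluoromethyl and iodo compared at this position, the compounds shown leave open how a chloro, a bromo, a nitrile or an amine would read there. They also leave open whether the iodo keeps its effect on the ring when the methoxy group is replaced by a hydroxyl or an ethoxy group.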